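The compounds below may be only part of what the source reports. "The series", "measured", "known", "first", "only" and "open" are said of these compounds alone.

Measured in an ADME assay on a cell-free system (plasma, Rattus norvegicus) for protein binding, using equilibrium dialysis; on this read-out higher numbers stand for a larger free fraction and lower numbers for a smaller free fraction:
- Compound 1 `O=S(=O)(c1ccc(F)cc1)c1cc(Cl)c(O)c2ncccc12`: 0.5
- Compound 2 `O=S(=O)(c1cc(F)c(O)c2ncccc12)C1CCCC1`: 0.2

Of these two numbers, compound 2 holds the lower one at 0.2, and its gap to compound 1 lies beyond the usual scatter of repeated measurements. Compound 3 `O=S(=O)(c1cc(Cl)c(O)c2ncccc12)C1CCCC1` is compound 2 with one change: chloro in place of fluoro on an aromatic carbon, ortho to a hydroxy group. Within the data shown here, no measured pair shows this swap on its own. Compound 1 carries chloro in that place and reads 0.5, but it also differs from compound 3 elsewhere, so it gives only a loose guide. No clear shift in this assay is therefore expected. The estimated step of a 1.1-fold lower number from compound 2 to compound 3 (0.05 log units; within the scatter) stays within the scatter. For compound 3 the expected unbound fraction is 0.18, with an estimated range of 0.08 to 0.4.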

Compound 3, unbound fraction: 0.5
The estimate for compound 3 lay 2.8-fold (0.44 log units) below the measured number; the whole stated range lies below it.
By their numbers in this assay, from the lowest: compound 2; then compounds 1 and 3 (each within the scatter of the next).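

With cyclopentyl kept on the sulfonyl sulfur, chloro in place of fluoro on the aromatic carbon ortho to the hydroxy group gives a 2.5-fold higher number from compound 2 to compound 3 (0.40 log units; beyond the scatter) in this assay, so this one-atom swap is enough on its own to move the read-out in this pair. With chloro kept in that place, cyclopentyl in place of 4-fluorophenyl on a sulfonyl sulfur gives no change at the digits printed from compound 1 to compound 3 (within the scatter), so in this pair the change of group on the sulfur leaves the read-out where it was. Nothing shown here explains why the halogen swap moves the number.

Still open, as far as these compounds go, is whether fluoro to chloro gives a similar step with 4-fluorophenyl on the sulfonyl sulfur. Also open, from the compounds shown here alone, is how a methyl, a methoxy or a nitrile on that aromatic carbon, or an amine or a carboxylic acid on the cyclopentyl, would read.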